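Methoxy to trifluoromethoxy from compound 2

The source may report more compounds than this note shows. Statements on the series, on what has been measured and on what is new or still open speak of the compounds shown alone.

In a functional assay on HUVEC cells (Homo sapiens) for inhibition, with a stated time of 4 days (a higher number here means a weaker inhibitor, a lower number a stronger inhibitor), compound 1 (`COc1ccc(C(N)=O)cc1/C=C/c1ccccc1C`) gives 2300 nM and compound 2 (`COc1ccccc1/C=C/c1cc(C(N)=O)ccc1OC`) gives 5700 nM as the higher of the two numbers. Within the data shown here, the only measured step is a 2.5-fold higher number from compound 1 to compound 2 (0.39 log units; beyond the scatter) with methoxy in place of methyl on an aromatic carbon. Compound 3 (`COc1ccc(C(N)=O)cc1/C=C/c1ccccc1OC(F)(F)F`) differs from compound 2 by trifluoromethyl in place of methyl on an oxygen on an aromatic ring as trifluoromethyl in place of methyl on an oxygen on an aromatic ring. Among the measured compounds shown here, no measured step covers this change, so a step no larger than the measured one is expected in this assay and it leans tentatively toward a lower number. The expected step is a 1.9-fold lower number from compound 2 to compound 3 (0.28 log units; within the scatter) on this estimate. The estimate for compound 3 is 3000 nM within an expected range of 1000 nM to 9000 nM overall.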

Compound 3, half-maximal inhibitory concentration: 8900 nM
Compound 3: middle estimate off by 3.0-fold (0.47 log units), on the low side; the range from low to high includes it.
By their numbers in this assay, from the lowest: compound 1; then compounds 2 and 3 (each within the scatter of the next).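

In this assay, trifluoromethyl in place of methyl on an oxygen on an aromatic ring gives a 1.6-fold higher number from compound 2 to compound 3 (0.19 log units; within the scatter) and so does not separate the two compounds. Trifluoromethoxy in place of methyl on an aromatic carbon gives a 3.9-fold higher number from compound 1 to compound 3 (0.59 log units; beyond the scatter) and thus, like methoxy, leaves this place on the higher-number side of compound 1. No available evidence bears on these steps. Still open, on these data alone, is how a hydroxyl, an amine or a longer alkoxy chain would read at this place. As far as these compounds go, whether the same change holds on another core also remains open.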